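The source may report more compounds than this note shows. Statements on the series, on what has been measured and on what is new or still open speak of the compounds shown alone.

Measured compounds in this study:
compound 1 `CCCCCCNc1nc(SCc2ccc(C(F)(F)F)cc2)nc2ccccc12` with 24300 nM
compound 2 `COc1ccccc1Nc1nc(SCc2ccc(C(F)(F)F)cc2)nc2ccccc12` with > 50000 nM
compound 3 `FC(F)(F)c1ccc(CSc2nc(Nc3cccc(Br)c3)c3ccccc3n2)cc1` with 25600 nM

In a functional assay on MCF7 cells (Homo sapiens) for cytotoxicity, read by MTT assay, with a stated time of 72 h (on this read-out lower numbers stand for stronger inhibition and higher numbers for weaker inhibition), compound 3 gives 25600 nM. Compound 1 and compound 3 lie within the scatter of one another, as the step of a 1.1-fold higher number from compound 1 to compound 3 (0.02 log units; within the scatter) shows. Compound 2 reports only a limit in this assay, > 50000 nM (the limit of > 50000 nM in this assay, at which 1 of the 3 values shown sits).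

Compound 4 is `Fc1ccc(Nc2nc(SCc3ccc(C(F)(F)F)cc3)nc3ccccc23)cc1`; it differs from compound 3 in one place: 4-fluorophenyl in place of 3-bromophenyl on a nitrogen on an aromatic ring. Among the measured compounds shown here, three measured steps touch this nitrogen. The step of a 1.1-fold higher number from compound 1 to compound 3 (0.02 log units; within the scatter) shows that swapping hexyl for 3-bromophenyl leaves the number where it was; the step of an at least 2.0-fold higher number from compound 1 to compound 2 (0.31 log units; beyond the scatter) shows that 2-methoxyphenyl raises it; the step of an at least 1.9-fold lower number from compound 2 to compound 3 (0.29 log units; that floor lies within the scatter) lowers it again, though its floor stays within the scatter. A change from one substituted phenyl to another at this nitrogen has so far moved the number only modestly, so compound 4 is expected to show a step of a 1.1-fold higher number from compound 3 to compound 4 (0.04 log units; within the scatter) that stays within the scatter. Compound 4 is therefore estimated at 28000 nM, between 12000 nM and 60000 nM.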

Compound 4, half-maximal inhibitory concentration: 36300 nM
Compound 4: middle estimate off by 1.3-fold (0.11 log units), on the low side; the measured number falls inside the stated range.
By their numbers in this assay, from the lowest: compounds 1, 3 and 4 (each within the scatter of the next). At a limit, above all of these: compound 2.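

In this assay, replacing 3-bromophenyl with 4-fluorophenyl, which changes both the halogen and where it sits on the ring, gives a 1.4-fold higher number from compound 3 to compound 4 (0.15 log units; within the scatter). The hexyl comparison gives a 1.5-fold higher number from compound 1 to compound 4 (0.17 log units; within the scatter), so hexyl, 3-bromophenyl and 4-fluorophenyl on this nitrogen all remain within the scatter of one another, and only 2-methoxyphenyl may go against this pattern. Compound 2 stands at a limit, so an at least 1.3-fold lower number from compound 2 to compound 4 (0.13 log units; that floor lies within the scatter) gives only a floor and does not separate 2-methoxyphenyl from 4-fluorophenyl: the limit of > 50000 nM in this assay, at which 1 of the 4 values shown sits.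

The compounds shown leave open whether a phenyl ring carrying a carboxylic acid or an amine, or a chain longer than hexyl, would move the number on this nitrogen beyond the scatter. They also leave open whether these small differences would hold with another group in place of the 4-(trifluoromethyl)benzyl group on sulfur.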